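Swapping a phenyl for a methoxy at the limit

The source may hold more compounds than are shown below. What is called first, only, known or untested is meant among the compounds shown, and "the series" means these compounds.

Compound 1 `CCOC(=O)c1c(-c2cccc(OC)c2)[nH]c2cc(OC)ccc2c1=O` gives > 21500 nM
Compound 2 `CCOC(=O)c1c(-c2cccc(OC)c2)[nH]c2cc(OC)c(OC)cc2c1=O` gives > 21500 nM
Compound 3 `CCOC(=O)c1c(-c2cccc(-c3ccccc3)c2)[nH]c2cc(OC)c(Cl)cc2c1=O` gives > 21500 nM

All three entries come from an ADME assay on HepG2 cells (Homo sapiens) for cytotoxicity, read by luminescence, with a stated time of 72 h (a lower number here means that less compound is needed, a higher number that more compound is needed for the effect), and each is a limit of the assay, not a number. Compound 3 therefore stands only at a limit, and the whole picture so far is the limit of > 21500 nM in this assay, at which 3 of the 3 values shown sit.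

Compound 4 `CCOC(=O)c1c(-c2cccc(OC)c2)[nH]c2cc(OC)c(Cl)cc2c1=O` has not yet been measured. It differs from compound 3 by a single change, (methoxy in place of phenyl on an aromatic carbon), which puts methoxy in place of phenyl on an aromatic carbon.

Within the data shown here, only one measured step bears on this, and only loosely. It is a step that the two limits leave unreadable from compound 1 to compound 2, and it concerns methoxy in place of hydrogen, so it offers no size to carry over. No step beyond the usual scatter can be forecast in this assay because the limit of > 21500 nM in this assay, at which 3 of the 3 values shown sit, is all that the numbers show, and compound 4 is expected to report a limit too.

The estimated step is a step that the limit leaves unreadable from compound 3 to compound 4 and its direction cannot be told with any confidence. For compound 4 the estimated value is 30000 nM, with an expected range from 18000 nM to 50000 nM.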

Compound 4, half-maximal effective concentration: > 21500 nM
Compound 4 was reported as a limit; the forecaster's own chance of this, stated with the estimate: 85%; the middle value does not contradict the limit.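

Compound 4 also gives only a limit in this assay, so no step from compound 1, compound 2 or compound 3 to compound 4 can be read: the limit of > 21500 nM in this assay, at which 4 of the 4 values shown sit.

The compounds shown leave open whether these four differ at all in this assay, and what change would bring a value inside the measurable range.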